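Swapping anilino for 4-methylpiperidin-1-yl on the benzamide scaffold

A few compounds are considered here, and "the series" means these few. Any claim that something is new, unique, unknown or untested is made for them only; others in the source may bear on it.

Compound 2 `Nc1ccccc1NC(=O)c1ccc(Cn2cnc3c(Nc4ccccc4)nc(Cl)nc32)cc1` stands highest of the three compounds in a functional assay on NCI-H460 cells (Homo sapiens) for antiproliferative activity, read by CCK-8 assay, with a stated time of 72 h, tested at 8 uM (on this read-out higher numbers stand for a stronger effect at the one concentration tested and lower numbers for a weaker effect), where compound 2 gives 77.8%. Compound 3 `Nc1ccccc1NC(=O)c1ccc(Cn2cnc3c(Nc4ccc(-c5ccccn5)cc4)nc(Cl)nc32)cc1` gives 30.8%, and compound 1 `CC1CCN(c2nc(Cl)nc3c2ncn3Cc2ccc(/C=C/C(=O)Nc3ccccc3N)cc2)CC1` gives 10.8%. For the measured compounds named here, the one measured step in the set, a number 47 percentage points lower from compound 2 to compound 3 (beyond the scatter), shows how sharply a single substituent change can cut the read-out. Compound 4 `CC1CCN(c2nc(Cl)nc3c2ncn3Cc2ccc(C(=O)Nc3ccccc3N)cc2)CC1` differs from compound 2 in one place: 4-methylpiperidin-1-yl in place of anilino on an aromatic carbon. Going by the values given here, no measured step covers this exchange; compound 1 carries the same 4-methylpiperidin-1-yl group, on a different linker, and its read-out is far below that of compound 2. A downward step in this assay is therefore expected, a number 47.8 percentage points lower from compound 2 to compound 4 (beyond the scatter). Compound 4 is estimated at 30%, between 8% and 60%.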

Compound 4, a percentage reported as inhibition, at one concentration (the size of the read-out at that concentration, not a potency): 40.9%
Beside the measured number, compound 4's estimate is 10.9 percentage points below it; measured number inside the range.
By their numbers in this assay, from the lowest: compound 1; then compound 3; then compound 4; then compound 2.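

In this assay there is a number 36.9 percentage points lower from compound 2 to compound 4 (beyond the scatter) when 4-methylpiperidin-1-yl replaces anilino on the aromatic carbon next to the ring nitrogen, so this position keeps part of the read-out without the aromatic ring of anilino. The low number of compound 1 does not follow from 4-methylpiperidin-1-yl alone: there is a number 30.1 percentage points higher from compound 1 to compound 4 (beyond the scatter) when (2-aminophenyl)carbamoyl replaces 2-((2-aminophenyl)carbamoyl)ethenyl with that group kept. No evidence on the reason for either step is at hand.

As far as these compounds go, whether morpholin-4-yl or dimethylamino at this position would stay nearer compound 2 remains open. So does the effect of the ethenyl linker when anilino is present.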